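Butyl in place of phenethyl on the imidazole of compound 3

This account rests on a few compounds, and the source may have more. Where it says the series, first, only, none or still open, it means among the compounds named here.

Compound 3 `O=C(O)c1ccccc1-c1ccc(CCc2ncc(CCc3ccccc3)[nH]2)cc1` stands highest among the three measured compounds in an in vitro functional assay on cells for agonist activity at Bombesin receptor subtype-3 (Homo sapiens), read by luminescence and calcium flux (a higher number here means that more compound is needed for the effect, a lower number that less compound is needed), at 1320 nM. Compound 1 `O=C(O)c1ccccc1-c1ccc(CCc2ncc(C3CCCCC3)[nH]2)cc1` gives 375 nM, and compound 2 `O=C(O)c1ccccc1-c1ccc(CCc2ncc(CC3CCCC3)[nH]2)cc1` gives 133 nM. Compound 4 `CCCCc1cnc(CCc2ccc(-c3ccccc3C(=O)O)cc2)[nH]1` differs from compound 3 by ethyl in place of phenyl on a saturated chain carbon, two bonds along the chain from an aromatic carbon. For the measured compounds named here, two measured steps bear on this: a 9.9-fold higher number from compound 2 to compound 3 (1.00 log units; beyond the scatter) and a 3.5-fold higher number from compound 1 to compound 3 (0.55 log units; beyond the scatter), both of which put an aromatic ring into the side chain and raised the number. The change to compound 4 removes that ring, so compound 4 is expected to move the other way, with a modest step of a 3.3-fold lower number from compound 3 to compound 4 (0.52 log units; beyond the scatter). Compound 4 is therefore estimated to give 400 nM in this assay, with a range from 150 nM to 1100 nM.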

Compound 4, half-maximal effective concentration: 2710 nM
The estimate for compound 4 lay 6.8-fold (0.83 log units) below the measured number, outside the stated range (above it).
By their numbers in this assay, from the lowest: compound 2; then compound 1; then compound 3; then compound 4.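

Taking the ring off the side chain did not lower the number: butyl in place of phenethyl gave a 2.1-fold higher number from compound 3 to compound 4 (0.31 log units; beyond the scatter) and not a drop, so an aromatic ring alone does not separate compound 3 from the two lower compounds. Butyl also stands behind both saturated rings, with a 20-fold higher number from compound 2 to compound 4 (1.31 log units; beyond the scatter) for the change from cyclopentylmethyl and a 7.2-fold higher number from compound 1 to compound 4 (0.86 log units; beyond the scatter) for the change from cyclohexyl. Nothing given here explains these differences. Still open, on these data alone, is whether a cyclobutylmethyl group or a branched chain such as isobutyl would keep the lower numbers.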